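Adding a methyl to the phenylsulfonyl group of compound 1

The source may report more compounds than this note shows. Statements on the series, on what has been measured and on what is new or still open speak of the compounds shown alone.

- Compound 1 `Cn1c(=O)c(S(=O)(=O)c2ccccc2)cc2cnc(Nc3ccc4ncccc4c3)nc21`: 50000 nM
- Compound 2 `Cn1c(=O)c(S(=O)(=O)c2ccccc2)cc2cnc(Nc3ccc4cc[nH]c4c3)nc21`: 10000 nM

In a functional assay on DU-145 cells (Homo sapiens) for inhibition, read by trypan blue exclusion, with a stated time of 72 h (on this read-out lower numbers stand for stronger inhibition and higher numbers for weaker inhibition), compound 1 has the higher of the two numbers, so it is the weaker inhibitor of the pair. Compound 3 `Cc1ccc(S(=O)(=O)c2cc3cnc(Nc4ccc5ncccc5c4)nc3n(C)c2=O)cc1` differs from it in one place: methyl in place of hydrogen on an aromatic carbon. Among the measured compounds shown here, the only measured step, a 5.0-fold lower number from compound 1 to compound 2 (0.70 log units; beyond the scatter), exchanges quinolin-6-yl, a group that compound 3 keeps, so no measured step touches the phenyl ring. No step beyond the scatter is therefore expected in this assay, and no direction can be favoured. The expected change is a 1.3-fold lower number from compound 1 to compound 3 (0.10 log units; within the scatter). For compound 3 the estimate is 40000 nM, with an expected range from 12000 nM to 100000 nM.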

Compound 3, half-maximal inhibitory concentration: 10000 nM
Estimate against measurement, compound 3: 4.0-fold (0.60 log units) above, and the stated range ends above it.
By their numbers in this assay, from the lowest: compounds 2 and 3 (each within the scatter of the next); then compound 1.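

In this assay, methyl in place of hydrogen on this aromatic carbon gives a 5.0-fold lower number from compound 1 to compound 3 (0.70 log units; beyond the scatter), so the phenyl ring of the phenylsulfonyl group, which the earlier step left untouched, also matters for this read-out. A single added carbon here moves the number as far as the larger exchange on the other side of the molecule, a 5.0-fold lower number from compound 1 to compound 2 (0.70 log units; beyond the scatter). No measurement shown here explains the change.

As far as these compounds go, whether a chlorine, a methoxy or an ethyl in the same place would act like the methyl remains open. So does whether the methyl would have the same effect on compound 2.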